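A few compounds are considered here, and "the series" means these few. Any claim that something is new, unique, unknown or untested is made for them only; others in the source may bear on it.

Measured compounds in a functional assay on HCT-116 cells (Homo sapiens), read by MTT assay, with a stated time of 72 h; a lower number here means a stronger inhibitor, a higher number a weaker inhibitor:

- Compound 1, `COc1ncnc2c1c(I)cn2[C@@H]1O[C@H](CO)[C@@H](O)[C@H]1O`: > 20000 nM
- Compound 2, `C#Cc1cn([C@@H]2O[C@H](CO)[C@@H](O)[C@H]2O)c2ncnc(OC)c12`: 4060 nM
- Compound 3, `COc1ncnc2c1c(-c1ccco1)cn2[C@@H]1O[C@H](CO)[C@@H](O)[C@H]1O`: 40 nM

The value of compound 1 in this assay is a limit of the assay, not a number (the limit of > 20000 nM in this assay, at which 1 of the 3 values shown sits). Of the two numbers shown, compound 2 gives the highest; the nearest is compound 3, with a 100-fold lower number from compound 2 to compound 3 (2.01 log units; beyond the scatter). The step of an at least 4.9-fold lower number from compound 1 to compound 2 (0.69 log units; beyond the scatter) and the step of an at least 500-fold lower number from compound 1 to compound 3 (2.69 log units; beyond the scatter) both change only the group on the five-membered ring carbon, as does the step from compound 2 to compound 3.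

Compound 4, `C#Cc1cn([C@@H]2O[C@H](CO)[C@@H](O)[C@H]2O)c2ncnc(N(C)C)c12`, is not yet measured in this assay. It differs from compound 2 by dimethylamino in place of methoxy on an aromatic carbon. For the measured compounds named here, none of the measured steps touches this position: every step recorded so far exchanges iodo, ethynyl or furan-2-yl on the aromatic carbon of the five-membered ring, and the methoxy group is held constant across compounds 1, 2 and 3. Going by the values given here, no measured step therefore bears on the change from compound 2 to compound 4, and there is no ground in these data for expecting a step in either direction beyond the scatter.

Compound 4 is accordingly expected to come near compound 2, at an estimated 6000 nM with a range of 1500 nM to 25000 nM. On these data alone, the expected step is a 1.5-fold higher number from compound 2 to compound 4 (0.17 log units; within the scatter), with the wide range reflecting that the position is untested here.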

Compound 4, half-maximal inhibitory concentration: 180 nM
Estimate against measurement, compound 4: 33-fold (1.52 log units) above; measured number below the stated range.
By their numbers in this assay, from the lowest: compound 3; then compound 4; then compound 2. At a limit, above all of these: compound 1.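

In this assay, the aromatic carbon of the six-membered aromatic ring with 2 nitrogen, which carries methoxy in compound 1, compound 2 and compound 3, proves to be a position that matters: dimethylamino in place of methoxy gives a 23-fold lower number from compound 2 to compound 4 (1.35 log units; beyond the scatter). For the compounds shown here, the number in this assay therefore responds to this position as well as to the group on the five-membered ring carbon, the only place changed among the earlier compounds. Methoxy and dimethylamino have the same counts of hydrogen-bond donors and acceptors and neither has a net charge, so those counts do not separate the two groups, and nothing shown accounts for the size of the step.

Dimethylamino is shown only together with ethynyl, so it remains open whether the same exchange would lower the number to a similar extent alongside furan-2-yl or iodo on the five-membered ring carbon. Also open, on these data alone, is how the unsubstituted amine, methylamino or a cyclic amine such as pyrrolidine would stand at this position against dimethylamino and methoxy.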